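A few compounds are considered here, and "the series" means these few. Any claim that something is new, unique, unknown or untested is made for them only; others in the source may bear on it.

Measured compounds:
- compound 1, `C=C(COC(=O)CC(C)C)c1ccc(C)cc1O`: 18300 nM
- compound 2, `C/C=C(\C)C(=O)Oc1cc(C)ccc1C1(COC(C)=O)CO1`: 25800 nM

Both compounds were tested in a functional assay on cells (Neutrophil, Homo sapiens) for inhibition, with a stated time of 5 min; on this read-out lower numbers stand for stronger inhibition and higher numbers for weaker inhibition. In this assay compound 1 gives 18300 nM, and compound 2 gives 25800 nM. The two numbers lie within the usual scatter of each other, so neither compound can be set apart from the other on this read-out. Going by the values given here, no pair of measured compounds differs in a single place, so there is no measured step to lean on.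

Compound 3, `C=C(COC(=O)C(C)C)c1ccc(C)cc1O`, has not yet been measured in this assay. It differs from compound 1 in one place: isopropyl in place of isobutyl on a carbonyl carbon. The chain on the carbonyl carbon is thus shortened by one carbon, while nothing else in the molecule changes. Among the compounds with values here, with no measured step of this kind available, the expected step from compound 1 to compound 3 is a 1.0-fold lower number from compound 1 to compound 3 (0.01 log units; within the scatter), that is, no step beyond the scatter. Compound 3 is therefore expected to give about 18000 nM in this assay, within a range from 7000 nM to 45000 nM.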

Compound 3, half-maximal inhibitory concentration: 16100 nM
Beside the measured number, compound 3's estimate is 1.1-fold (0.05 log units) above it; the range from low to high includes it.
By their numbers in this assay, from the lowest: compounds 3, 1 and 2 (each within the scatter of the next).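

Going by these compounds alone, this is the first measured step, and it concerns the chain on the carbonyl carbon, where the ester oxygen is the other neighbour. In this assay, putting isopropyl in place of isobutyl gives a step that stays within the scatter (a 1.1-fold lower number from compound 1 to compound 3 (0.06 log units; within the scatter)), so this single change leaves the inhibition read-out effectively unchanged. No measurement available here explains this result or links it to any property of the two groups.

The step covers only two closely related branched alkyl groups, so it cannot show how far this position would accept something different. As far as these compounds go, whether a longer chain such as hexyl, a phenyl ring or an amine on this carbonyl carbon would move the number beyond the scatter remains open.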